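Shifting the chlorine pattern on a weak cytotoxic lead

The source may hold more compounds than are shown below. What is called first, only, known or untested is meant among the compounds shown, and "the series" means these compounds.

Among the compounds with values here, compound 2 `C=CCn1c(=O)/c(=C\c2ccccc2Cl)[nH]c(=O)/c1=C\c1ccccc1OC` is the only compound in this set with a number to its name. In a functional assay on HL-60 cells (Homo sapiens) for cytotoxicity, read by CCK-8 assay, with a stated time of 72 h (a lower number here means a stronger inhibitor, a higher number a weaker inhibitor), compound 2 gives 4200 nM, a weak result by the standards of such measurements. The other measured compound, compound 1 `COc1ccccc1/C=c1/[nH]c(=O)/c(=C\c2cccc(Cl)c2Cl)[nH]c1=O`, carries a 2,3-dichlorophenyl and an unsubstituted ring nitrogen, and in this assay compound 1 is recorded as "not active" (no number reported), so no comparison of size can be drawn between it and compound 2; the two differ in more than one place.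

Compound 3 `C=CCn1c(=O)/c(=C\c2ccc(Cl)c(Cl)c2)[nH]c(=O)/c1=C\c1ccccc1OC` keeps the allyl group and the methoxyphenyl of compound 2 and changes only one arm: 3,4-dichlorophenyl in place of 2-chlorophenyl on a double-bonded chain carbon bound to an aromatic carbon. Within the data shown here, no measured pair in the set isolates this change, so the direction of the step is open. Given that compound 1, the one other dichlorophenyl entry, was found not active, the step from compound 2 to compound 3 is expected to be small, with a slight lean toward weaker inhibition, a 1.4-fold higher number from compound 2 to compound 3 (0.15 log units; within the scatter). For compound 3 in this assay an estimated value of 6000 nM is expected, within a range from 1800 nM to 20000 nM.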

Compound 3, half-maximal inhibitory concentration: "not active" (no number reported)
For compound 3 the study gives words and no number; there is nothing to compare the estimate with.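

In this assay compound 3 is recorded as "not active" (no number reported), and with a number for compound 2 alone, no step can be read between compound 2 and compound 3. The compounds shown leave open how the 3,4-dichlorophenyl and 2-chlorophenyl arms compare in size of effect. Nothing measured here offers an explanation for this result.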